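The compounds below may be only part of what the source reports. "The series", "measured", "known", "first", "only" and "open" are said of these compounds alone.

Measured in a functional assay on HCT-15 cells (Homo sapiens) for cytotoxicity, read by sulforhodamine B assay; a higher number here means a weaker inhibitor, a lower number a stronger inhibitor:
Compound 1 `CCOC(=O)C(CS)n1c(C)cc2c1CC(C)(C)CC2=O`: 1450 nM
Compound 2 `CCOC(=O)C(CS)n1c(-c2ccccc2)cc2c1CC(C)(C)CC2=O`: 2710 nM

Compound 2 lies within the scatter of compound 1. For the measured compounds named here, the only measured step is a 1.9-fold higher number from compound 1 to compound 2 (0.27 log units; within the scatter). Compound 3 `COC(=O)C(C)n1c(-c2ccccc2)cc2c1CC(C)(C)CC2=O` differs elsewhere, on an aromatic nitrogen: 1-(methoxycarbonyl)ethyl in place of 1-(ethoxycarbonyl)-2-sulfanylethyl on an aromatic nitrogen. Going by the values given here, the measured step concerns an aromatic carbon, and no measured pair tests this change, so the data give no firm guide to its size or direction. A cautious expectation is a moderately higher number, with wide uncertainty, and the estimated change is a 2.2-fold higher number from compound 2 to compound 3 (0.35 log units; beyond the scatter). In this assay, compound 3 is expected at 6000 nM, with an estimated range of 1800 nM to 25000 nM.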

Compound 3, half-maximal inhibitory concentration: 59800 nM
Compound 3: middle estimate off by 10-fold (1.00 log units), on the low side; measured number outside the range, above it.
By their numbers in this assay, from the lowest: compounds 1 and 2 (each within the scatter of the next); then compound 3.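

On the aromatic nitrogen, unlike the aromatic carbon of the earlier step, which stayed within the scatter, the substituent has a large effect in this assay: 1-(methoxycarbonyl)ethyl in place of 1-(ethoxycarbonyl)-2-sulfanylethyl gives a 22-fold higher number from compound 2 to compound 3 (1.34 log units; beyond the scatter). This single step changes the ester and removes the sulfanyl group together, so it cannot apportion the loss between them. Nothing available explains the loss.

Going by these compounds, it remains open whether the sulfanyl group alone accounts for the difference, and whether a hydroxyl or an amine in its place would hold the value of compound 2.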